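Aryl group on the ring nitrogen: step to compound 4

This account rests on a few compounds, and the source may have more. Where it says the series, first, only, none or still open, it means among the compounds named here.

Three members of the series have been measured in a functional assay on B16-F10 cells (Mus musculus) for inhibition, read by MTT assay, with a stated time of 72 h; on this read-out lower numbers stand for stronger inhibition and higher numbers for weaker inhibition. Compound 1 `N#Cc1c(Nc2ccc(Cl)cc2)nc(SCc2cn(Cc3ccccc3Cl)nn2)nc1-c1ccccc1` gives 1590 nM, compound 2 `N#Cc1c(Nc2cccc(Cl)c2)nc(SCc2cn(Cc3ccccc3Cl)nn2)nc1-c1ccccc1` gives 3590 nM, and compound 3 `Cc1cccc(Nc2nc(SCc3cn(Cc4ccccc4Cl)nn3)nc(-c3ccccc3)c2C#N)c1` gives 13500 nM. Compound 3 therefore carries the highest number of the three, with compound 2 nearest and compound 1 furthest away. The steps between them are a 2.3-fold higher number from compound 1 to compound 2 (0.35 log units; beyond the scatter), an 8.5-fold higher number from compound 1 to compound 3 (0.93 log units; beyond the scatter) and a 3.8-fold higher number from compound 2 to compound 3 (0.58 log units; beyond the scatter); each lies beyond the scatter, so the group on the ring nitrogen is where the numbers move in this set.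

Compound 4 `N#Cc1c(Nc2ccccc2F)nc(SCc2cn(Cc3ccccc3Cl)nn2)nc1-c1ccccc1` is not yet measured. Its change from compound 3 is 2-fluorophenyl in place of 3-methylphenyl on a nitrogen on an aromatic ring. Within the data shown here, no measured step exchanges 3-methylphenyl for 2-fluorophenyl, so the bearing is indirect. What the set does show is that compound 3 sits highest and both chlorophenyl variants sit lower, as a 3.8-fold higher number from compound 2 to compound 3 (0.58 log units; beyond the scatter) and an 8.5-fold higher number from compound 1 to compound 3 (0.93 log units; beyond the scatter) make plain, so leaving 3-methylphenyl is expected to lower the number in this assay rather than raise it. Because of a 3.8-fold higher number from compound 2 to compound 3 (0.58 log units; beyond the scatter) the expected move is modest rather than large. Compound 4 is accordingly expected near 4000 nM, within a range of 1300 nM to 12000 nM. The estimated step is a 3.4-fold lower number from compound 3 to compound 4 (0.53 log units; beyond the scatter).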

Compound 4, half-maximal inhibitory concentration: 5230 nM
The estimate for compound 4 lay 1.3-fold (0.12 log units) below the measured number, and the stated range covers the measured number.
By their numbers in this assay, from the lowest: compound 1; then compounds 2 and 4 (each within the scatter of the next); then compound 3.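

In this assay the change from 3-methylphenyl to 2-fluorophenyl on a nitrogen on an aromatic ring gives a lower number (a 2.6-fold lower number from compound 3 to compound 4 (0.41 log units; beyond the scatter)), so a fluoro-bearing phenyl group joins the two chloro-bearing ones below compound 3. Among the four compounds, 3-methylphenyl is the only group with a methyl and carries the highest number, and none of compounds 1, 2 or 4 goes against this. Compound 4 cannot be separated from compound 2 (a 1.5-fold higher number from compound 2 to compound 4 (0.16 log units; within the scatter)), while 4-chlorophenyl remains the group with the lowest number (a 3.3-fold higher number from compound 1 to compound 4 (0.52 log units; beyond the scatter)), so the position responds to more than the mere presence of a halogen.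

The 2-fluorophenyl and 3-chlorophenyl groups differ in both the substituent and its place on the phenyl ring, so the compounds shown do not separate these two contributions, and they leave open how 2-chlorophenyl, 4-fluorophenyl, 4-methylphenyl, unsubstituted phenyl, or a phenyl bearing an amine or a carboxylic acid would read here. No evidence on hand accounts for the differences among these groups.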